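The source may hold more compounds than are shown below. What is called first, only, known or untested is meant among the compounds shown, and "the series" means these compounds.

Measured so far:
compound 1, `Cc1cccc(C)c1-n1ncc(C(=O)Nc2ccc3ccccc3n2)c1C`, in a functional assay on SW480 cells (Homo sapiens) for inhibition; a lower number here means a stronger inhibitor of growth, a higher number a weaker inhibitor of growth: 7200 nM
compound 2, `Cc1ccc(C)c(-n2ncc(C(=O)Nc3ccc4ccccc4n3)c2C)c1`, in this assay: 24600 nM

Compound 2 stands at the highest of the two numbers; its nearest neighbour is compound 1, from which it is separated by a 3.4-fold higher number from compound 1 to compound 2 (0.53 log units; beyond the scatter), a step that came with the change from 2,6-dimethylphenyl to 2,5-dimethylphenyl on the aromatic nitrogen.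

Compound 3, `CCc1ccccc1-n1ncc(C(=O)Nc2ccc3ccccc3n2)c1C`, has not yet been measured in this assay. It differs from compound 2 by 2-ethylphenyl in place of 2,5-dimethylphenyl on an aromatic nitrogen. Going by the values given here, only one measured step bears on this change, a 3.4-fold higher number from compound 1 to compound 2 (0.53 log units; beyond the scatter), and it shows that rearranging the same two carbons on the phenyl ring shifted the number by a modest, but real, amount. Compound 3 again keeps the same atoms and moves them; a step of similar modest size is therefore expected, most likely back toward a lower number, as a 2.1-fold lower number from compound 2 to compound 3 (0.31 log units; beyond the scatter). Compound 3 is thus estimated at 12000 nM, with a range from 4000 nM to 36000 nM.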

Compound 3, concentration for 50% growth inhibition: 9700 nM
Compound 3: middle estimate off by 1.2-fold (0.09 log units), on the high side, within the range that was stated.
By their numbers in this assay, from the lowest: compounds 1 and 3 (each within the scatter of the next); then compound 2.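

In this assay, 2-ethylphenyl in place of 2,5-dimethylphenyl gave a 2.5-fold lower number from compound 2 to compound 3 (0.40 log units; beyond the scatter) on the aromatic nitrogen, so a second rearrangement of the same atoms within this group also shifted the number, this time downward. Replacing 2,6-dimethylphenyl with the same 2-ethylphenyl gave a 1.3-fold higher number from compound 1 to compound 3 (0.13 log units; within the scatter) and so does not separate these two groups, leaving compound 2 as the only one of the three set apart by steps beyond the scatter to both others. Nothing available explains why the 2,5-dimethylphenyl group differs from the other two.

The compounds shown leave open how an unsubstituted phenyl, a 2-propylphenyl or a 2-methoxyphenyl would compare at this nitrogen. They also leave open whether an amine or a carboxylic acid on this ring would be tolerated in this growth read-out.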